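The source may hold more compounds than are shown below. What is called first, only, known or untested is meant among the compounds shown, and "the series" means these compounds.

Two members of this series have so far been run through an ADME assay on microsomes from liver (Homo sapiens) for metabolic stability, read by LC-MS, using NADPH, with stated times of 5 min and 30 min, tested at 1 uM; a higher number here means faster removal of the compound, a lower number slower removal. Compound 1 `CN(C)C(=O)c1cc(-c2cnc(NCc3c(F)ccc4c3CCO4)c3cn[nH]c(=O)c23)n(C)n1` gives 21 mL.min-1.g-1 in this assay and holds the lowest of the two numbers recorded; compound 2 `Cc1ncccc1-c1cnc(NCc2c(F)ccc3c2CCO3)n2c(=O)[nH]nc12` gives 36 mL.min-1.g-1 in this assay, which is the nearest number, and the gap between compound 1 and compound 2 falls within the scatter of the measurement, so no order is read from it. Compound 3 `Cc1nc(CO)ccc1-c1cnc(NCc2c(F)ccc3c2CCO3)c2cn[nH]c(=O)c12` is not yet measured. Against compound 1 it carries one change: 6-(hydroxymethyl)-2-methylpyridin-3-yl in place of 3-(dimethylcarbamoyl)-1-methyl-1H-pyrazol-5-yl on an aromatic carbon. Going by the values given here, no measured pair in the set shows this exchange, so nothing in the numbers fixes its direction, and the two measured values sit so close together that they offer only a narrow anchor. For compound 3 the expectation is therefore for no movement beyond the scatter, with the number placed near the spread of compound 1 and compound 2 rather than outside it. The expected step is a 1.4-fold higher number from compound 1 to compound 3 (0.15 log units; within the scatter). Compound 3 is thus expected to give 30 mL.min-1.g-1 in this assay, within the range 12 mL.min-1.g-1 to 75 mL.min-1.g-1.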

Compound 3, intrinsic clearance in microsomes: 11 mL.min-1.g-1
Compound 3: the middle estimate sits 2.7-fold (0.44 log units) above what was measured; the whole stated range lies above it.
By their numbers in this assay, from the lowest: compounds 3, 1 and 2 (each within the scatter of the next, the first and the last beyond it).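

In this assay, the exchange of 3-(dimethylcarbamoyl)-1-methyl-1H-pyrazol-5-yl for 6-(hydroxymethyl)-2-methylpyridin-3-yl on an aromatic carbon comes with a 1.9-fold lower number from compound 1 to compound 3 (0.28 log units; within the scatter) and so sets no order between the two compounds. Going by these compounds alone, this pair is the first direct reading at this position, para to a large group on the shared core, and it shows that a five-membered aromatic ring carrying a dimethylcarbamoyl group and a six-membered aromatic ring carrying a hydroxymethyl group can replace each other without a step beyond the scatter. No measurement on hand bears on what lies behind this step.

The compounds shown leave open whether a methoxymethyl group, an aminomethyl group or a carboxylic acid in place of the hydroxymethyl group would give a step beyond the scatter in this assay on the core of compound 3. Also open, from the compounds shown here alone, is what the ring methyl of the 6-(hydroxymethyl)-2-methylpyridin-3-yl group contributes, which a matched pair with a hydrogen in its place would read directly.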